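The compounds below may be only part of what the source reports. "The series", "measured", "known", "first", "only" and "open" are said of these compounds alone.

Of the compounds shown here, three have been measured so far, and a fourth is waiting. Compound 1 `COc1cc(/C=C/C(=O)C2=C(/C=C/c3ccc(O)c(OC)c3)NC(=O)NC2c2ccccc2)ccc1O`, compound 2 `COc1cc(/C=C/C(=O)C2=C(/C=C/c3ccc(O)c(OC)c3)NC(=O)NC2c2ccccc2Cl)ccc1O` and compound 3 `COc1cc(/C=C/C(=O)C2=C(/C=C/c3ccc(O)c(OC)c3)NC(=S)NC2c2c(Cl)cccc2Cl)ccc1O` were all tested in a functional assay, with a stated time of 20 min, tested at 2 uM; a lower number here means a weaker effect, a higher number a stronger effect of the compound at the concentration tested. Compound 1 gives 10.5%, compound 2 gives 16.6% and compound 3 gives 15%. The three numbers sit close together, and none of the gaps between them is larger than the usual scatter of this kind of measurement.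

Compound 1 and compound 2 differ in one place only, by hydrogen in place of chloro on an aromatic carbon. This change made a step of a number 6.1 percentage points lower from compound 2 to compound 1 (within the scatter), a step that lies within the scatter and therefore cannot be read as a real difference between the two compounds.

Compound 3 has a different core from compound 2; the difference between the two cores is not broken down here. The unmeasured compound 4 `COc1cc(/C=C/C(=O)C2=C(/C=C/c3ccc(O)c(OC)c3)NC(=S)NC2c2ccccc2Cl)ccc1O` is derived from compound 3 by hydrogen in place of chloro on an aromatic carbon. Among the measured compounds shown here, this is the same kind of change as the one from compound 2 to compound 1, but not the same: in compound 3 the affected carbon is also meta to a chloro group, which is not so in compound 2.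

Because the earlier step of a number 6.1 percentage points lower from compound 2 to compound 1 (within the scatter) was small, a similarly small step is expected here, of about a number 3 percentage points lower from compound 3 to compound 4 (within the scatter) in this assay. Compound 4 is therefore estimated at 12%, most likely between 4% and 20%.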

Compound 4, a percentage reported as activity, at one concentration (the size of the read-out at that concentration, not a potency): 15.5%
Estimate against measurement, compound 4: 3.5 percentage points below; the measured number falls inside the stated range.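

Replacing chloro by hydrogen, which turns 2,6-dichlorophenyl into 2-chlorophenyl, gives a step of a number 0.5 percentage points higher from compound 3 to compound 4 (within the scatter) in this assay, and this can be set beside the same kind of change on the other core: the same change on two cores in this assay, a number 6.1 percentage points lower (within the scatter) from compound 2 to compound 1 and a number 0.5 percentage points higher (within the scatter) from compound 3 to compound 4, 6.6 percentage points apart, within the scatter of two such steps. So far the change carries from one core to the other only in a limited sense: neither step stands out from the scatter, and the two steps cannot be told apart from each other. This does not show that removing a chloro group never matters, or that the two cores respond alike, since two small steps at a single tested concentration are too little to set a rule, and the chloro group leaves a ring with no other chloro on one core but with a second one on the other.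

The compounds shown leave open how a plain phenyl group would read on the core of compound 3, and whether a step beyond the scatter would appear at other concentrations. They also leave open what a different group on this ring would do in place of chloro, such as a methoxy group, a nitro group or an amine.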